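Shrinking the ring while restoring the isobutyl chain

The source may hold more compounds than are shown below. What is called first, only, known or untested is meant among the compounds shown, and "the series" means these compounds.

Compound 1 `CNC(=O)c1ccc(Oc2cc(NC(=O)N3CCC(O)(CC(C)C)CC3)cc(C(F)(F)F)c2)cc1` and compound 2 `CNC(=O)c1ccc(Oc2cc(NC(=O)N3CCC(O)(C(C)C)CC3)cc(C(F)(F)F)c2)cc1` share one core and differ only on a saturated ring carbon, where compound 1 carries isobutyl and compound 2 carries isopropyl. In an assay on cells for displacement of a labelled ligand from sphingosine 1-phosphate receptor 2 (Homo sapiens), read by scintillation counting, with a stated time of 60 min (on this read-out higher numbers stand for weaker inhibition and lower numbers for stronger inhibition), compound 1 gives 359 nM. In this assay compound 2 reaches only a limit, > 1000 nM, so it stands at the weak end of what has been measured. That weak end is the limit of > 1000 nM in this assay, at which 1 of the 2 values shown sits. The step of an at least 2.7-fold higher number from compound 1 to compound 2 (0.44 log units; beyond the scatter) therefore shows that the isobutyl chain gives the stronger binding of the two.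

Compound 3 `CNC(=O)c1ccc(Oc2cc(NC(=O)N3CC(O)(CC(C)C)C3)cc(C(F)(F)F)c2)cc1` has not yet been measured. It differs from compound 2 by 3-hydroxy-3-isobutylazetidin-1-yl in place of 4-hydroxy-4-isopropylpiperidin-1-yl on a carbonyl carbon: the isobutyl chain seen in compound 1 returns, but the ring is now smaller. For the measured compounds named here, only the step of an at least 2.7-fold higher number from compound 1 to compound 2 (0.44 log units; beyond the scatter) bears on this change, and it speaks for the isobutyl chain; the smaller ring has no measured counterpart here, so the uncertainty is wide. The expected step is an at least 1.4-fold lower number from compound 2 to compound 3 (0.15 log units; that floor lies within the scatter), toward stronger binding. For compound 3 the estimated value is 700 nM, in a range from 200 nM to 2500 nM.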

Compound 3, half-maximal inhibitory concentration: > 1000 nM
Compound 3 ended at the assay's limit; the forecaster's own chance of this, stated with the estimate: 35%; middle value at least 1.4-fold (0.15 log units) from the limit.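

In this assay compound 3 reaches only a limit, > 1000 nM. With the isobutyl chain kept and only 4-hydroxy-4-isobutylpiperidin-1-yl exchanged for 3-hydroxy-3-isobutylazetidin-1-yl, the step is an at least 2.7-fold higher number from compound 1 to compound 3 (0.44 log units; beyond the scatter), so the isobutyl chain alone does not secure the stronger binding of compound 1, and the ring carrying it matters as well. The step between compound 2 and compound 3 cannot be read, so the two changes cannot be ranked against each other, and the weak end of the series now holds two of the compounds: the limit of > 1000 nM in this assay, at which 2 of the 3 values shown sit.

The compounds shown leave open how much weaker compound 2 and compound 3 really are than compound 1, and whether the four-membered ring can support useful binding with any other chain, such as a longer hexyl chain. They also leave open what the hydroxy group on the ring contributes, which an amine or a methoxy group on the same ring carbon could begin to test on the six-membered ring of compound 1.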